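Replacing a carbamate side chain with a hydroxyethyl piperidine

A few compounds are considered here, and "the series" means these few. Any claim that something is new, unique, unknown or untested is made for them only; others in the source may bear on it.

Compound 1, `CC(C)(C)OC(=O)NC1CCN(C(=O)CN2CN(c3ccccc3)C3(CCN(C(=O)c4ccc(C(C)(C)C)cc4)CC3)C2=O)CC1`, in an assay on HEK293 cells for displacement of a labelled ligand from NPC1-like intracellular cholesterol transporter 1 (Homo sapiens); a lower number here means a stronger inhibitor, a higher number a weaker inhibitor: 8300 nM
Compound 2, `CC(C)(C)OC(=O)NCCCNC(=O)CN1CN(c2ccccc2)C2(CCN(C(=O)c3ccc(C4CCCCC4)cc3)CC2)C1=O`: 6000 nM
Compound 3, `CC(C)(C)OC(=O)NCCCNC(=O)CN1CN(c2ccccc2)C2(CCN(C(=O)c3ccc(C(C)(C)C)cc3)CC2)C1=O`: 4500 nM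

All three measured compounds share the same core and differ only in their side groups. Going by the values given here, their numbers sit close together: the one measured step, a 1.3-fold lower number from compound 2 to compound 3 (0.12 log units; within the scatter), is within the scatter, and the gap between compound 3 and compound 1 is within the scatter as well, so none of the three can be set apart from the others on these data.

Compound 4, `CC(C)(C)c1ccc(C(=O)N2CCC3(CC2)C(=O)N(CC(=O)N2CCCCC2CCO)CN3c2ccccc2)cc1`, keeps the tert-butyl on the aromatic carbon of compound 3 and changes the other end of the molecule: 2-(2-hydroxyethyl)piperidin-1-yl in place of (3-((tert-butoxycarbonyl)amino)propyl)amino on a carbonyl carbon. Among the compounds with values here, no measured step touches this part of the structure; the single measured step concerns the aromatic substituent instead, and it was small. There is therefore nothing to suggest a change in this assay beyond the scatter, but equally nothing to rule one out.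

Compound 4 is expected to give about 5000 nM in this assay, within a range from 1500 nM to 20000 nM. The step this estimate implies, a 1.1-fold higher number from compound 3 to compound 4 (0.05 log units; within the scatter), is expected to remain within the scatter.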

Compound 4, half-maximal inhibitory concentration: 6100 nM
For compound 4 the middle estimate is 1.2-fold (0.09 log units) below the measured one, and the stated range covers the measured number.
By their numbers in this assay, from the lowest: compounds 3, 2, 4 and 1 (each within the scatter of the next).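

In this assay, going by these compounds alone, this is the first look at the group on the carbonyl carbon, and swapping the open carbamate chain for a ring-bearing alcohol gives a 1.4-fold higher number from compound 3 to compound 4 (0.13 log units; within the scatter) and so no readable change. The exchange is not a subtle one: the tert-butoxycarbonyl group goes entirely, the entering group has fewer heavy atoms than the one it replaces, a six-membered non-aromatic ring enters, and the hydrogen-bond donors and acceptors each become fewer. For this pair, then, the carbamate is not needed to keep the number where it is, and a large change in the shape of the side chain leaves the result within the scatter, although no measurement here bears on why that is so.

From the compounds shown here alone, it remains open whether anything at this position can move the number beyond the scatter, for instance a plain piperidin-1-yl without the hydroxyethyl arm, a longer chain ending in a hydroxyl, or a carboxylic acid. Also unsettled is whether cyclohexyl and tert-butyl on the aromatic carbon would stay as close together with 2-(2-hydroxyethyl)piperidin-1-yl at the other end as they do with the carbamate chain.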